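A few compounds are considered here, and "the series" means these few. Any claim that something is new, unique, unknown or untested is made for them only; others in the source may bear on it.

Measured in an ADME assay on the whole organism for pharmacokinetics, with Rattus norvegicus as the target; a higher number here means that more of the compound sits outside the plasma, a lower number that more of the compound stays in the plasma:
Compound 1 `O=S(=O)(c1ccc(O)c2ncccc12)C1CCCC1`: 1.8 L/kg
Compound 2 `O=S(=O)(c1ccc(F)cc1)c1cc(Cl)c(O)c2ncccc12`: 0.23 L/kg
Compound 3 `O=S(=O)(c1cc(F)c(O)c2ncccc12)C1CCCC1`: 0.41 L/kg

Compound 3 stands clearly under compound 1, and the values of compound 3 and compound 2 lie within the usual scatter of each other. Compound 4 `O=S(=O)(c1cc(Cl)c(O)c2ncccc12)C1CCCC1` differs from compound 3 in one place: chloro in place of fluoro on an aromatic carbon, ortho to a hydroxy group. Among the measured compounds shown here, no measured step makes this exchange directly. The closest evidence is a 4.4-fold lower number from compound 1 to compound 3 (0.64 log units; beyond the scatter) on going from hydrogen to fluoro at that carbon, a modest step beyond the scatter. Compound 2 also carries chloro on the core, but its sulfonyl partner differs, and in this assay compound 2 reads 0.23 L/kg, so it offers only indirect support. Among these three compounds, those with a halogen give the lower values. The exchange is therefore expected to produce no change beyond the scatter, with an expected 1.0-fold lower number from compound 3 to compound 4 (0.01 log units; within the scatter) in this read-out. For compound 4 the estimate is 0.4 L/kg, with an expected range from 0.2 L/kg to 0.8 L/kg around it.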

Compound 4, volume of distribution at steady state: 0.3 L/kg
The estimate for compound 4 lay 1.3-fold (0.12 log units) above the measured number, within the range that was stated.
By their numbers in this assay, from the lowest: compounds 2, 4 and 3 (each within the scatter of the next); then compound 1.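

In this assay, the position ortho to a hydroxy group now has two halogens that can be compared directly: chloro in place of fluoro gives (a 1.4-fold lower number from compound 3 to compound 4 (0.14 log units; within the scatter)), while chloro in place of hydrogen gives (a 6.0-fold lower number from compound 1 to compound 4 (0.78 log units; beyond the scatter)), so among compounds 1, 3 and 4 the halogen-bearing compounds stand apart from the hydrogen compound, whichever halogen is present. With chloro held fixed, cyclopentyl in place of 4-fluorophenyl on the sulfonyl sulfur gives (a 1.3-fold higher number from compound 2 to compound 4 (0.12 log units; within the scatter)), so this pair does not separate the two sulfonyl partners. Nothing measured here explains these results.

The compounds shown leave open whether a group other than a halogen at this carbon, such as a methoxy group or an amine, would track with fluoro and chloro. They also leave open how a longer chain on the sulfonyl sulfur would read.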